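A few compounds are considered here, and "the series" means these few. Any claim that something is new, unique, unknown or untested is made for them only; others in the source may bear on it.

Measured compounds:
Compound 1, `CCc1ccc(NC2=CC(=O)c3c(nc4n3[C@H]3OC[C@@H](O)[C@H]3OC4)C2=O)cc1`: > 4000 nM
Compound 2, `O=C1C=C(Nc2cccc(F)c2)C(=O)c2c1nc1n2[C@H]2OC[C@@H](O)[C@H]2OC1`: 7030 nM

The two measured compounds share a core and differ only in the group carried on the amine nitrogen. In a functional assay on ECa-109 cells for inhibition, with ECa-109 cell line (Homo sapiens) as the target, read by sulforhodamine B assay (on this read-out lower numbers stand for stronger inhibition and higher numbers for weaker inhibition), compound 1 gives > 4000 nM, which is a limit of the assay and not a number. Where compound 1 stands is therefore known only as the limit of > 4000 nM in this assay, at which 1 of the 2 values shown sits. Compound 2, measured in this assay, gives 7030 nM. For the measured compounds named here, no step between compound 1 and compound 2 has been worked out, so the two values are all that can be said of that pair.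

Compound 3, `O=C1C(NC2CCCCC2)=CC(=O)c2c1nc1n2[C@H]2OC[C@@H](O)[C@H]2OC1`, has not yet been measured. It differs from compound 1 in one place: cyclohexyl in place of 4-ethylphenyl on an amine nitrogen. Nothing measured here tells how a cyclohexyl on that nitrogen compares with a 4-ethylphenyl, so the expected step is a step that the limit leaves unreadable from compound 1 to compound 3, none beyond the usual scatter of this assay. Compound 3 is accordingly estimated to give around 6000 nM, with a range from 2000 nM to 20000 nM, and a fair chance that only a limit is reported.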

Compound 3, half-maximal inhibitory concentration: > 16000 nM
Compound 3: a limit, no number; the forecaster's own chance of this, stated with the estimate: 45%; middle value at least 2.6-fold (0.42 log units) away from the limit.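

Compound 1 and compound 3 are each reported in this assay only as a limit of the assay and not as a number, so no step can be read between them. As far as these compounds go, how a cyclohexyl on the amine nitrogen compares with a 4-ethylphenyl there remains open, as does the actual potency of either compound.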